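A few compounds are considered here, and "the series" means these few. Any claim that something is new, unique, unknown or untested is made for them only; others in the source may bear on it.

Among the compounds with values here, in a functional assay on FM3A cells (Mus musculus) for antiproliferative activity, read by cell counting, with a stated time of 2 days (on this read-out higher numbers stand for weaker inhibition and lower numbers for stronger inhibition), only two compounds have been read so far. Compound 1 `COc1cc(C(=O)c2sc(N(C)Cc3ccccc3)nc2N)cc(OC)c1OC` gives > 200000 nM, which is a limit of the assay and not a number. Compound 2 `COc1ccc(C(=O)c2sc(N3CCCC3)nc2N)cc1` gives > 200000 nM, and this too is a limit and not a number. Compound 2 therefore has no exact value, and it sits with compound 1 at the limit of > 200000 nM in this assay, at which 2 of the 2 values shown sit.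

Compound 3 `Nc1nc(N2CCCC2)sc1C(=O)c1ccccc1` has not yet been measured. It differs from compound 2 in one place, with hydrogen in place of methoxy on an aromatic carbon, para to a large group: hydrogen in place of methoxy on an aromatic carbon. Within the data shown here, no measured pair in this assay shows what a change of this kind does, so the expectation has only these two compounds to rest on. No clear gain in inhibition is expected because the limit of > 200000 nM in this assay, at which 2 of the 2 values shown sit, applies to both compound 1 and compound 2. The estimated change, a number no higher from compound 2 to compound 3 (the limit leaves the size open), is expected to stay within the usual scatter. For compound 3 the expected value is 200000 nM, with an estimated range from 60000 nM to 300000 nM.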

Compound 3, half-maximal inhibitory concentration: > 200000 nM
Compound 3 gave a limit, no number; the forecaster's own chance of this, stated with the estimate: 85%; the middle value sits exactly at the limit.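

In this assay compound 2 and compound 3 both give a limit and not a number, so no step can be read between them, and the picture stays as it was: the limit of > 200000 nM in this assay, at which 3 of the 3 values shown sit. The compounds shown leave open what hydrogen in place of methoxy does to inhibition, and which changes to these structures would give a readable number.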